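Swapping the Amide Group: Forecast for Compound 4

A few compounds are considered here, and "the series" means these few. Any claim that something is new, unique, unknown or untested is made for them only; others in the source may bear on it.

Three amides share one core and were tested in a functional assay on HT-29 cells (Homo sapiens) for cytotoxicity, read by MTT assay, with a stated time of 72 h; on this read-out lower numbers stand for stronger inhibition and higher numbers for weaker inhibition. Compound 1 `CN1[C@@H]2c3[nH]c4ccccc4c3C[C@H]1[C@H](C#N)N1[C@@H](CNC(=O)c3cccc4c3CCCC4)c3[nH]c4ccccc4c3C[C@@H]21` gives 3340 nM, compound 2 `CN1[C@@H]2c3[nH]c4ccccc4c3C[C@H]1[C@H](C#N)N1[C@@H](CNC(=O)c3cc4ccccc4o3)c3[nH]c4ccccc4c3C[C@@H]21` gives 850 nM, and compound 3 `CN1[C@@H]2c3[nH]c4ccccc4c3C[C@H]1[C@H](C#N)N1[C@@H](CNC(=O)c3cc4ccccc4[nH]3)c3[nH]c4ccccc4c3C[C@@H]21` gives 1220 nM. The steps of a 3.9-fold lower number from compound 1 to compound 2 (0.59 log units; beyond the scatter) and a 2.7-fold lower number from compound 1 to compound 3 (0.44 log units; beyond the scatter) were modest, while a 1.4-fold higher number from compound 2 to compound 3 (0.16 log units; within the scatter) lies within the scatter, so compound 3 sits second highest of the three, close to compound 2 and clearly apart from compound 1. Compound 4 `CN1[C@@H]2c3[nH]c4ccccc4c3C[C@H]1[C@H](C#N)N1[C@@H](CNC(=O)/C=C/c3cccc(C(F)(F)F)c3)c3[nH]c4ccccc4c3C[C@@H]21` carries 2-(3-(trifluoromethyl)phenyl)ethenyl in place of 1H-indol-2-yl on a carbonyl carbon. Going by the values given here, no measured step involves this entering group; the measured steps only show that exchanging the acyl group shifts this assay modestly. A small step is therefore expected, a 1.6-fold higher number from compound 3 to compound 4 (0.21 log units; within the scatter). The number for compound 4 is estimated at 2000 nM, within a range of 600 nM to 6500 nM.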

Compound 4, half-maximal inhibitory concentration: 5060 nM
Compound 4: the middle estimate sits 2.5-fold (0.40 log units) below what was measured, and the stated range covers the measured number.
By their numbers in this assay, from the lowest: compounds 2 and 3 (each within the scatter of the next); then compounds 1 and 4 (each within the scatter of the next).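

At this position on the carbonyl carbon, 2-(3-(trifluoromethyl)phenyl)ethenyl does worse than 1H-indol-2-yl, with a 4.1-fold higher number from compound 3 to compound 4 (0.62 log units; beyond the scatter) beyond the scatter, and worse than 1-benzofuran-2-yl, with a 6.0-fold higher number from compound 2 to compound 4 (0.77 log units; beyond the scatter) also beyond it. Against 1,2,3,4-tetrahydronaphthalen-5-yl, a 1.5-fold higher number from compound 1 to compound 4 (0.18 log units; within the scatter) leaves those two groups indistinguishable, so the four acyl groups now form two pairs. Nothing measured here explains this split.

The compounds shown do not separate the part played by the double bond from that of the trifluoromethyl group. Going by these compounds, how an amine or a carboxylic acid on the acyl group would score also remains open.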